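The compounds below may be only part of what the source reports. "The series", "measured", "known", "first", "only" and "open" are said of these compounds alone.

In a functional assay on G-361 cells (Homo sapiens) for inhibition, with a stated time of 72 h (on this read-out higher numbers stand for weaker inhibition and lower numbers for stronger inhibition), compound 1 `NC1CCC(Nc2nc(NCc3ccc(-c4ccco4)cc3)c3ncn(C4CCCC4)c3n2)CC1` gives 164 nM, the middle of three numbers. Compound 3 `NC1CCC(Nc2nc(NCc3ccc(-c4cccc(F)c4)nc3)c3ncn(C4CCCC4)c3n2)CC1` reads lower at 49 nM, and compound 2 `CC(C)(O)CNc1nc(NCc2ccc(-c3ccco3)cc2)c2ncn(C3CCCC3)c2n1` reads higher at 17400 nM. Next in the series is compound 4 `Nc1ccccc1CNc1nc(NC2CCC(N)CC2)nc2c1ncn2C1CCCC1`, with this change from compound 1: 2-aminophenyl in place of 4-(furan-2-yl)phenyl on a saturated chain carbon bound to a nitrogen on an aromatic ring. Within the data shown here, no measured step covers that change. Among the measured compounds shown here, the only step available, a 110-fold higher number from compound 1 to compound 2 (2.03 log units; beyond the scatter), concerns the 4-aminocyclohexyl group, which compound 4 keeps, so it shows only that one replacement can move this assay strongly. For the measured compounds named here, no measured compound carries 2-aminophenyl, and the direction remains a judgement. The expected step, moderate and upward, is a 4.9-fold higher number from compound 1 to compound 4 (0.69 log units; beyond the scatter). Compound 4 is estimated at 800 nM, with an expected range of 200 nM to 4000 nM.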

Compound 4, half-maximal inhibitory concentration: 2070 nM
For compound 4 the middle estimate is 2.6-fold (0.41 log units) below the measured one; the measured number falls inside the stated range.
By their numbers in this assay, from the lowest: compound 3; then compound 1; then compound 4; then compound 2.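

Among these compounds, the step of a 13-fold higher number from compound 1 to compound 4 (1.10 log units; beyond the scatter) is the first measured change on this saturated chain carbon, read in this assay with the 4-aminocyclohexyl group held constant. It shows that this place, too, moves the read-out beyond the scatter, and that 2-aminophenyl is the less favourable of the two groups tested here. No available evidence accounts for the size of this step.

The result does not separate the loss of the furan-2-yl ring from the entry of the amine. An unsubstituted phenyl group at this place, on the core of compound 1, would divide those two changes.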